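Cytotoxicity notes: pyridyl isomer swap on compound 1

The source may report more compounds than this note shows. Statements on the series, on what has been measured and on what is new or still open speak of the compounds shown alone.

Measured so far:
compound 1, `O=S(=O)(Cc1nc(-c2ccncc2)c2sccc2n1)c1cccc(Cl)c1`: > 50000 nM
compound 2, `CCC1=C(C(=O)OCC2CCCCC2)C(c2cccc(O)c2)NC(=O)N1`: > 10000 nM

Both measurements come from an ADME assay on cells (Homo sapiens) for cytotoxicity, read by resazurin assay, with a stated time of 5 days; a higher number here means that more compound is tolerated, a lower number that less compound is tolerated. Compound 1 returns only a limit in this assay, > 50000 nM, so no number is known for it. Compound 2 also returns only a limit, > 10000 nM. Where compound 1 stands is therefore a matter of limits, not of numbers: it sits at the limit of > 50000 nM in this assay, at which 1 of the 2 values shown sits, while the one other value sits at the limit of > 10000 nM in this assay, at which 1 of the 2 values shown sits. Neither compound is tied to a measured concentration at which cells are affected.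

Compound 3, `O=S(=O)(Cc1nc(-c2cccnc2)c2sccc2n1)c1cccc(Cl)c1`, differs from compound 1 in a single place: pyridin-3-yl in place of pyridin-4-yl on an aromatic carbon. Going by the values given here, no step between measured compounds that differ in one place is available, so no measured comparison gives a sense of how large such a change might be in this assay. The expectation is for no step beyond the usual scatter, in either direction; the move from compound 1 to compound 3 is estimated as a number no higher from compound 1 to compound 3 (the limit leaves the size open). For compound 3 the expected value in this assay is 50000 nM, with a range from 20000 nM to 100000 nM, and most probably once more only a limit rather than a number.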

Compound 3, half-maximal cytotoxic concentration: > 50000 nM
Compound 3 was reported as a limit; the forecaster's own chance of this, stated with the estimate: 75%; the middle value lies on the limit itself.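

Compound 1 and compound 3 both return only a limit in this assay, so no step can be read for the swap of pyridin-4-yl to pyridin-3-yl: the limit of > 50000 nM in this assay, at which 2 of the 3 values shown sit.

The compounds shown leave open at what concentration compound 1 and compound 3 affect cells, and whether the two differ at all in this assay.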